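Shared-core series with sulfur-bearing substituents: working notes

The source may report more compounds than this note shows. Statements on the series, on what has been measured and on what is new or still open speak of the compounds shown alone.

Three measured compounds share one core and differ only in the group on the five-membered aromatic ring. Compound 1 `CCCCCSc1nnc(COc2cc(C)c3c(C)cc(=O)oc3c2)o1` carries a pentylsulfanyl group. In a functional assay on MCF7 cells (Homo sapiens) for antiproliferative activity, read by MTT assay, with a stated time of 24 h (a higher number here means a weaker inhibitor, a lower number a stronger inhibitor), compound 1 gives only a limit, > 100000 nM. Compound 2 `CCCCCCSc1nnc(COc2cc(C)c3c(C)cc(=O)oc3c2)o1` differs from compound 1 by methyl in place of hydrogen on a saturated chain carbon, five bonds along the chain from a sulfur. In this assay compound 2 likewise gives only a limit, > 100000 nM. The step is a step that the two limits leave unreadable from compound 1 to compound 2. Compound 3 `CCS(=O)(=O)c1nnc(COc2cc(C)c3c(C)cc(=O)oc3c2)o1` differs from compound 1 by ethylsulfonyl in place of pentylsulfanyl on an aromatic carbon; this is how the substituent of compound 3 and compound 4 departs from that of compound 1 and compound 2. In this assay compound 3 also gives only a limit, > 100000 nM. The step is a step that the two limits leave unreadable from compound 1 to compound 3, and likewise a step that the two limits leave unreadable from compound 2 to compound 3. Everything measured so far sits at the limit of > 100000 nM in this assay, at which 3 of the 3 values shown sit.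

Compound 4 `CCCS(=O)(=O)c1nnc(COc2cc(C)c3c(C)cc(=O)oc3c2)o1` is not yet measured; it differs from compound 3 by methyl in place of hydrogen on a saturated chain carbon, two bonds along the chain from a sulfonyl sulfur. Going by the values given here, this is the same kind of change as the one made from compound 1 to compound 2, though the place differs: there the entering methyl sits five bonds along the chain from a sulfur, here two bonds along the chain from a sulfonyl sulfur. From compound 3 to compound 4 the expected step is a step that the limit leaves unreadable from compound 3 to compound 4, since the comparable step read a step that the two limits leave unreadable from compound 1 to compound 2 and gave no sign of gain. Compound 4 is therefore expected near 150000 nM, estimated from 50000 nM to 500000 nM, most likely reported again as a limit.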

Compound 4, half-maximal inhibitory concentration: > 100000 nM
Compound 4 gave a limit, no number; the forecaster's own chance of this, stated with the estimate: 85%; the middle value lies beyond the limit too.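

In this assay compound 4 gives > 100000 nM, which is a limit and not a number. No step from compound 1, compound 2 or compound 3 to compound 4 can be read, with all four compounds sitting at the same limit: the limit of > 100000 nM in this assay, at which 4 of the 4 values shown sit.

The compounds shown leave open whether any substituent on the shared core gives a readable value in this assay, and therefore how sulfanyl and sulfonyl groups or their chains compare.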